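Hydrogen for hydroxy: the step from compound 1 to compound 4

A few compounds are considered here, and "the series" means these few. Any claim that something is new, unique, unknown or untested is made for them only; others in the source may bear on it.

Compound 1 `COc1ccc(/C=N/NC(=O)COc2cccc3ccccc23)cc1O` is the reference point of these notes. In an ADME assay on HEL cells (Homo sapiens) for cytotoxicity (a lower number here means that less compound is tolerated, a higher number that more compound is tolerated), compound 1 gives 100 ug/mL, the highest of the two numbers shown in the series. Compound 3 `O=C(COc1cccc2ccccc12)N/N=C/c1ccccc1[N+](=O)[O-]` in this assay gives 20 ug/mL, a lower number than compound 1 by a gap that lies beyond the usual scatter. Compound 2 `C/C(=N\NC(=O)COc1cccc2ccccc12)c1ccc(O)cc1O` in this assay gives > 100 ug/mL, which is a limit of the assay and not a number. the limit of > 100 ug/mL in this assay, at which 1 of the 3 values shown sits, marks where that limit sits.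

Compound 4 `COc1ccc(/C=N/NC(=O)COc2cccc3ccccc23)cc1` differs from compound 1 in one place: hydrogen in place of hydroxy on an aromatic carbon. Among the compounds with values here, no step between measured compounds in this assay covers this change, so no measured step tells how large it is. Within the data shown here, none of the measured pairs involves removing a hydroxy at such a place, and the size of this step therefore rests on general expectation alone. In this assay a step of no size beyond the scatter is expected, in either direction. Compound 4 is expected to give about 100 ug/mL in this assay, with a range from 50 ug/mL to 200 ug/mL. The estimated no change at the digits printed from compound 1 to compound 4 (within the scatter) thus stays within the scatter, and a limit reading rather than a number is also a fair possibility.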

Compound 4, minimum cytotoxic concentration: 20 ug/mL
Compound 4: the middle estimate sits 5.0-fold (0.70 log units) above what was measured; measured number outside the range, below it.
By their numbers in this assay, from the lowest: compounds 3 and 4 (each within the scatter of the next); then compound 1.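

In this assay, hydrogen in place of hydroxy on an aromatic carbon, ortho to a methoxy group, gives a 5.0-fold lower number from compound 1 to compound 4 (0.70 log units; beyond the scatter). Within the data shown here, as the only step between measured compounds that differ in one place, it shows that this position is not neutral: the loss of a single heavy atom, with the rest of compound 1 unchanged, is enough to take the number beyond the scatter, and the direction means that less compound is tolerated without the hydroxy. The measurements shown establish the size and direction of this step but do not bear on what lies behind it.

The compounds shown leave open whether another group on this aromatic carbon, such as an amine, a fluorine or an ethoxy, would keep the number of compound 1 or fall to that of compound 4. They also leave open whether the hydroxy carries the same weight when hydrogen stands in place of the methoxy group, or when the step is taken on a different core.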